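Amide-side ring exchange on the shared core: cytotoxicity notes

A few compounds are considered here, and "the series" means these few. Any claim that something is new, unique, unknown or untested is made for them only; others in the source may bear on it.

Among the compounds with values here, compound 2 `CC(C)(NC(=O)OCc1ccccc1)c1nc(O)c(O)c(C(=O)NCC2CC2)n1` gives 204000 nM in an ADME assay on C8166 cells (Homo sapiens) for cytotoxicity, read by MTT assay, with a stated time of 3 days (a lower number here means that less compound is tolerated, a higher number that more compound is tolerated), and stands as the lower of the two numbers so far. Compound 1 `Cc1ccc(CNC(=O)c2nc(C(C)(C)NC(=O)OCc3ccccc3)nc(O)c2O)cc1` gives 234000 nM in this assay, and the step of a 1.1-fold lower number from compound 1 to compound 2 (0.06 log units; within the scatter) is within the scatter, so the two compounds are not separated by this read-out. Compound 3 `CC(C)(NC(=O)OCc1ccccc1)c1nc(O)c(O)c(C(=O)NCc2ccccc2Cl)n1` has not been measured; it differs from compound 2 by 2-chlorophenyl in place of cyclopropyl on a saturated chain carbon bound to an amide-type nitrogen. Within the data shown here, only one measured step bears on this change: the step of a 1.1-fold lower number from compound 1 to compound 2 (0.06 log units; within the scatter), which also exchanged one ring for another at the same saturated chain carbon bound to the amide-type nitrogen and produced nothing beyond the scatter. From that single step, the expected move a 1.1-fold higher number from compound 2 to compound 3 (0.03 log units; within the scatter) is none beyond the scatter. Compound 3 is therefore estimated at 220000 nM, with a range from 100000 nM to 450000 nM.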

Compound 3, half-maximal cytotoxic concentration: 53900 nM
Estimate against measurement, compound 3: 4.1-fold (0.61 log units) above, outside the stated range (below it).
By their numbers in this assay, from the lowest: compound 3; then compounds 2 and 1 (each within the scatter of the next).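

In this assay this position does respond to the group it carries: 2-chlorophenyl on the saturated chain carbon bound to an amide-type nitrogen gives a 3.8-fold lower number from compound 2 to compound 3 (0.58 log units; beyond the scatter) and a 4.3-fold lower number from compound 1 to compound 3 (0.64 log units; beyond the scatter) and so marks the first separation in the series. Having a six-membered aromatic ring of carbon only at this place does not by itself set the number, since 4-methylphenyl stays within the scatter of cyclopropyl while 2-chlorophenyl does not. No measurement shown here accounts for this difference.

A plain phenyl at this place would help separate the contribution of the chlorine from that of the ring. Going by these compounds, how an amine or a carboxylic acid on the same chain carbon would read in this assay remains open.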